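The source may hold more compounds than are shown below. What is called first, only, known or untested is meant among the compounds shown, and "the series" means these compounds.

Measured so far:

Compound 1, `Clc1nc(NC2CC2)c2ncn(C3CCCCO3)c2n1`, 11.9% in a functional assay on the whole organism with Mus musculus as the target, with a stated time of 90 min, at a dose of 25 umol/kg by the oral route; on this read-out higher numbers stand for a stronger effect at the one dose given and lower numbers for a weaker effect.
Compound 2, `NC(=O)C[C@H](NC(=O)CN(c1nc(Cl)nc2c1ncn2C1CCCCO1)C1CC1)C(=O)OCc1ccccc1`, 35% in this assay.

Of the two numbers in hand, compound 2 stands highest; compound 1 lies a step lower, and that step is beyond the scatter. Among the compounds with values here, the two compounds differ at more than one place, so no single-point step is available between them, and only their two values can be compared.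

Compound 3, `O=C(CN(c1nc(Cl)nc2c1ncn2C1CCCCO1)C1CC1)N[C@@H](CO)C(=O)OCc1ccccc1`, is not yet measured in this assay. It differs from compound 2 in one place: hydroxy in place of carbamoyl on a saturated chain carbon, two bonds along the chain from an amide-type nitrogen and a carbonyl carbon. The shared core and the rest of the chain are kept.

With no measured step of this kind in the series, the size of the step from compound 2 to compound 3 can only be guessed. The expected change is small, with a slight lean downward, and likely to stay within the scatter: a number 5 percentage points lower from compound 2 to compound 3 (within the scatter). Compound 3 is accordingly expected to give 30% in this assay, with an estimated range from 12% to 50%.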

Compound 3, a percentage reported as activity, at one dose (the size of the read-out at that dose, not a potency): 32.2%
Beside the measured number, compound 3's estimate is 2.2 percentage points below it, within the range that was stated.
By their numbers in this assay, from the lowest: compound 1; then compounds 3 and 2 (each within the scatter of the next).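

The series now holds its first step that differs in one place, a number 2.8 percentage points lower from compound 2 to compound 3 (within the scatter), in this assay. At this saturated chain carbon, two bonds along the chain from an amide-type nitrogen and a carbonyl carbon, carbamoylmethyl can therefore give way to hydroxymethyl with no difference that stands clear of the scatter, although hydroxy carries fewer heavy atoms than carbamoyl and the two groups count the same hydrogen-bond donors and acceptors. No measurement in hand bears on why the read-out stays level across this change.

The compounds shown leave open what an amine, a carboxylic acid or a plain methyl group would give on this same chain carbon, and whether a longer chain ending in hydroxy or carbamoyl would read alike. Also open, as far as these compounds go, is whether this one pair, read at a single oral dose and a single time, would stay level at other doses or times, so no wider rule for this position can be drawn from it.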